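Widening the anilide of a boron-containing antiproliferative

The compounds below may be only part of what the source reports. "The series", "measured", "known", "first", "only" and "open" are said of these compounds alone.

As a free acid, compound 1 `O=C(O)CCc1cccc2c1B(O)OC2` stays at the limit of a functional assay on MDA-MB-231 cells (Homo sapiens) for antiproliferative activity, read by MTT assay, with a stated time of 72 h; a lower number here means a stronger inhibitor, a higher number a weaker inhibitor: compound 1 gives > 100000 nM, which is a limit rather than a number (the limit of > 100000 nM in this assay, at which 1 of the 3 values shown sits). Capping the acid as an anilide gives compound 2 `O=C(CCc1cccc2c1B(O)OC2)Nc1ccccc1`, which in this assay gives 230 nM, a step of an at least 430-fold lower number from compound 1 to compound 2 (2.63 log units; beyond the scatter). For the measured compounds named here, compound 2 stands lowest of the two numbers measured so far; the nearest is compound 3 `Cc1ccc(NC(=O)CCc2cccc3c2B(O)OC3)cc1`, which in this assay gives 1100 nM, a step of a 4.8-fold higher number from compound 2 to compound 3 (0.68 log units; beyond the scatter). Compound 4 `N#Cc1ccc(-c2cccc(NC(=O)CCc3cccc4c3B(O)OC4)c2)cc1` has not yet been measured; it differs from compound 2 by 4-cyanophenyl in place of hydrogen on an aromatic carbon. Going by the values given here, the only measured step that alters the anilide ring, from compound 2 to compound 3, was modest and weakening, so a step of similar size in the same direction is expected here, though the entering group is much larger and the uncertainty is wide. Compound 4 is therefore expected to give about 600 nM in this assay, between 150 nM and 3000 nM, a step of a 2.6-fold higher number from compound 2 to compound 4 (0.42 log units; beyond the scatter).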

Compound 4, half-maximal inhibitory concentration: 380 nM
Compound 4: middle estimate off by 1.6-fold (0.20 log units), on the high side; measured number inside the range.
By their numbers in this assay, from the lowest: compounds 2 and 4 (each within the scatter of the next); then compound 3. At a limit, above all of these: compound 1.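

In this assay, placing 4-cyanophenyl on an aromatic carbon of the anilide ring, meta to a large group, gives a 1.7-fold higher number from compound 2 to compound 4 (0.22 log units; within the scatter), so the two compounds read as alike. The anilide ring can therefore carry a second aromatic ring and a nitrile, 8 heavy atoms in all, without a change beyond the scatter, whereas the methyl change gave a 4.8-fold higher number from compound 2 to compound 3 (0.68 log units; beyond the scatter). The methyl and the 4-cyanophenyl differ in both group and place, and nothing shown accounts for the difference between these two steps.

On these data alone, it remains open whether the nitrile matters, or whether a plain phenyl or a phenyl bearing an amine or a carboxylic acid would read the same. As far as these compounds go, a methyl at this same place also remains untested, so the effect of the group cannot yet be separated from that of its place.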